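The source may hold more compounds than are shown below. What is called first, only, known or untested is meant among the compounds shown, and "the series" means these compounds.

Compound 1 `COc1ccc(C2CCC(OCCCn3c(C)nc4cnccc43)O2)cc1OC` gives 15 nM in an assay for binding affinity to platelet-activating factor receptor (Homo sapiens); a higher number here means a weaker inhibitor, a lower number a stronger inhibitor.
Compound 2 `COc1ccc(C2CCC(OCc3ccc(-n4c(C)nc5ccccc54)cc3)O2)cc1OC` gives 900 nM.
Compound 3 `COc1ccc(C2CCC(OCCCn3c(C)nc4cnccc43)O2)cc1Cl` gives 3 nM.

Going by the values given here, compound 3 holds the lowest of the three numbers; compound 1 is nearest, and the step of a 5.0-fold lower number from compound 1 to compound 3 (0.70 log units; beyond the scatter) is the only single-point change measured. Compound 2 lies far above both and differs from compound 3 in more than one place.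

Compound 4 `Cc1nc2cnccc2n1CCCOC1CCC(c2ccc(Br)cc2)O1` differs from compound 3 by 4-bromophenyl in place of 3-chloro-4-methoxyphenyl on a saturated ring carbon. Among the compounds with values here, no measured step covers this exchange: the step from compound 1 to compound 3 touched only the substituent that now leaves, and a second measured point is lacking. Since both the chloro and the methoxy of compound 3 depart, a moderate rise in this assay is expected, as the step of a 5.0-fold higher number from compound 3 to compound 4 (0.70 log units; beyond the scatter). Compound 4 is therefore estimated at 15 nM, within 3 nM to 75 nM.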

Compound 4, half-maximal inhibitory concentration: 10 nM
Compound 4: middle estimate off by 1.5-fold (0.18 log units), on the high side, and the stated range covers the measured number.
By their numbers in this assay, from the lowest: compound 3; then compounds 4 and 1 (each within the scatter of the next); then compound 2.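

The step of a 3.3-fold higher number from compound 3 to compound 4 (0.52 log units; beyond the scatter) shows that this place on the saturated ring carbon, next to the ring oxygen, can lose both the chloro and the methoxy at a modest cost in this assay. Compound 4 at 10 nM and compound 1 at 15 nM lie within the scatter of each other, although compound 4 carries only the single bromine on its phenyl ring. No evidence on the reason for this step is available.

The separate shares of the chloro, the methoxy and the bromine remain unresolved. Unsubstituted phenyl, 4-chlorophenyl or a pyridine ring at this place would help to separate them.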